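The source may hold more compounds than are shown below. What is called first, only, known or untested is meant among the compounds shown, and "the series" means these compounds.

Measured in an assay on HEK293 cells for inhibition of Steryl-sulfatase (Homo sapiens), tested at 0.1 uM; on this read-out higher numbers stand for a stronger effect at the one concentration tested and lower numbers for a weaker effect:
- compound 1, `CCN(Cc1ccc(F)cc1)c1cccc(C(=O)N2CCc3ccc(OS(N)(=O)=O)cc3C2)c1`, gives 10.9%
- compound 2, `NS(=O)(=O)Oc1ccc2c(c1)CN(C(=O)c1cccc(N3CCCCC3)c1)CC2`, gives 1%
- compound 3, `CC(C)CCN(CCC(C)C)c1cccc(C(=O)N2CCc3ccc(OS(N)(=O)=O)cc3C2)c1`, gives 32.3%

Compound 3 stands highest of the three in this assay: the nearest number is that of compound 1, and the step of a number 21.4 percentage points higher from compound 1 to compound 3 (beyond the scatter) lies beyond the scatter; the furthest is that of compound 2, reached by a number 31.3 percentage points higher from compound 2 to compound 3 (beyond the scatter). The remaining pair, compound 1 and compound 2, is separated only by a number 9.9 percentage points lower from compound 1 to compound 2 (within the scatter).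

The next compound, compound 4, is `CCN(Cc1cccc(Br)c1)c1cccc(C(=O)N2CCc3ccc(OS(N)(=O)=O)cc3C2)c1`. Relative to compound 3 it carries (3-bromobenzyl)(ethyl)amino in place of diisopentylamino on an aromatic carbon.

For the measured compounds named here, the step that bears most directly on this change is the one from compound 1 to compound 3, since compound 1 also carries an ethyl(benzyl)amino arrangement, differing from compound 4 only in the halogen and its placement on the benzyl ring. That step, a number 21.4 percentage points higher from compound 1 to compound 3 (beyond the scatter), was a modest rise; the change toward compound 4 goes the opposite way, so a drop of similar size is expected, a number 19.3 percentage points lower from compound 3 to compound 4 (beyond the scatter). Compound 4 is therefore estimated at 13%, most likely between 2% and 28%, close to compound 1.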

Compound 4, a percentage reported as inhibition, at one concentration (the size of the read-out at that concentration, not a potency): 20.9%
Estimate against measurement, compound 4: 7.9 percentage points below; the range from low to high includes it.
By their numbers in this assay, from the lowest: compounds 2, 1 and 4 (each within the scatter of the next, the first and the last beyond it); then compound 3.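

In this assay, 3-bromophenyl in place of 4-fluorophenyl on the ethyl(benzyl)amino arrangement gives a number 10 percentage points higher from compound 1 to compound 4 (within the scatter) and so does not separate the two compounds, even though both the halogen and its place on the ring differ. Against the two groups without a benzyl ring, the result points in opposite directions: (3-bromobenzyl)(ethyl)amino in place of diisopentylamino gives a number 11.4 percentage points lower from compound 3 to compound 4 (beyond the scatter) while the same group in place of piperidin-1-yl gives a number 19.9 percentage points higher from compound 2 to compound 4 (beyond the scatter) and thus places this group clearly apart from both. Diisopentylamino therefore stays alone at the top of this set, since its steps to all the other groups shown lie beyond the scatter, and nothing available here explains why these amino groups differ.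

On these data alone, it remains open whether an unsubstituted benzyl group, a 4-bromobenzyl group or a 3-methoxybenzyl group on the same nitrogen would also stay within the scatter of these two benzyl compounds. As far as these compounds go, it is also open whether diisobutylamino, with its shorter branched chains, or a morpholin-4-yl ring would fall nearer to diisopentylamino or to piperidin-1-yl.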